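The compounds below may be only part of what the source reports. "The series", "measured", "known", "first", "only" and "open" are said of these compounds alone.

In a functional assay on BXPC-3 cells (Homo sapiens) for antiproliferative activity, read by MTT assay, with a stated time of 24 h (a lower number here means a stronger inhibitor, a higher number a weaker inhibitor), compound 1 `CCn1c(C(=O)N[C@H](C)C(=O)OC)ccc1C(CC)(CC)c1ccc(OCS(=O)(=O)c2ccccc2)c(C)c1` gives > 50000 nM which is a limit of the assay and not a number. Compound 2 `CCn1c(C(=O)NCCC(=O)OC)ccc1C(CC)(CC)c1ccc(OCS(=O)(=O)c2ccccc2)c(C)c1` gives > 50000 nM which is likewise only a limit. Compound 3 `CCn1c(C(=O)N[C@@H](C)CO)ccc1C(CC)(CC)c1ccc(OCS(=O)(=O)c2ccccc2)c(C)c1` stands alone with a real number, 15300 nM for its half-maximal inhibitory concentration. Compound 4 `CCn1c(C(=O)NC2(CO)CC2)ccc1C(CC)(CC)c1ccc(OCS(=O)(=O)c2ccccc2)c(C)c1` carries 1-(hydroxymethyl)cyclopropyl in place of 1-(hydroxymethyl)ethyl on an amide-type nitrogen and the core stays the same. Two measured steps changed that same nitrogen substituent: an at least 3.2-fold lower number from compound 1 to compound 3 (0.51 log units; beyond the scatter) and an at least 3.2-fold lower number from compound 2 to compound 3 (0.51 log units; beyond the scatter) are both lower bounds on size. Both removed a methoxycarbonyl group, which this change does not do, so no step beyond the scatter is expected. The expected step is a 1.0-fold higher number from compound 3 to compound 4 (0.02 log units; within the scatter) in this estimate. Compound 4 is estimated at 16000 nM with a range from 6000 nM to 45000 nM in this assay when measured.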

Compound 4, half-maximal inhibitory concentration: 45400 nM
Estimate against measurement, compound 4: 2.8-fold (0.45 log units) below, and the stated range ends below it.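

In this assay, replacing 1-(hydroxymethyl)ethyl with 1-(hydroxymethyl)cyclopropyl on the amide-type nitrogen gives a 3.0-fold higher number from compound 3 to compound 4 (0.47 log units; beyond the scatter). For the compounds shown here, the hydroxymethyl group stays in both compounds, so this position responds to more than the loss of methoxycarbonyl seen in the earlier steps. Against the two methoxycarbonyl compounds, an at least 1.1-fold lower number from compound 2 to compound 4 (0.04 log units; that floor lies within the scatter) and an at least 1.1-fold lower number from compound 1 to compound 4 (0.04 log units; that floor lies within the scatter) are only floors, because those comparisons rest on a limit: the limit of > 50000 nM in this assay, at which 2 of the 4 values shown sit.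

As far as these compounds go, whether the three-membered ring itself or simply the larger group goes with the higher number remains open. Also open, from the compounds shown here alone, is how an amine, a carboxylic acid or a longer chain would behave at this position.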